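The source may hold more compounds than are shown below. What is called first, only, known or untested is meant among the compounds shown, and "the series" means these compounds.

In an ADME assay on CHO cells (Cricetulus griseus) for cytotoxicity, read by MTT assay; a higher number here means that more compound is tolerated, a lower number that less compound is tolerated:

- compound 1 `Fc1ccc(Nc2cc3[nH]c(Nc4ccc(N5CCNCC5)cn4)nc3cn2)cc1C(F)(F)F`: 14000 nM
- compound 2 `Fc1ccc(Nc2cc3[nH]c(Nc4ccc(N5CCN(CC6CC6)CC5)cn4)nc3cn2)cc1C(F)(F)F`: 41000 nM
- compound 3 `CC(C)(C)N1CCN(c2ccc(Nc3nc4cnc(Nc5cccc(C(F)(F)F)c5)cc4[nH]3)nc2)CC1`: 99000 nM

Compound 3 gives the highest of the three numbers, with 99000 nM standing beyond the scatter of both others. The next compound is compound 4 `FC(F)(F)c1cccc(Nc2cc3[nH]c(Nc4ccc(N5CCN(CC6CC6)CC5)cn4)nc3cn2)c1`, and the change from compound 3 is cyclopropylmethyl in place of tert-butyl on an amine nitrogen in a ring.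

Going by the values given here, no measured step covers this exchange directly. The nearest evidence is a 2.9-fold higher number from compound 1 to compound 2 (0.47 log units; beyond the scatter), a modest step that brings in the same cyclopropylmethyl, but in place of hydrogen. Compound 2, which carries cyclopropylmethyl, gives 41000 nM, although it also differs from compound 3 elsewhere. The data hold no direct comparison of tert-butyl and cyclopropylmethyl on otherwise identical compounds, so the direction is tentative. A modest move to a lower number in this assay is expected, towards the value of compound 2. The expected change is a 2.2-fold lower number from compound 3 to compound 4 (0.34 log units; beyond the scatter). For compound 4 the estimated value is 45000 nM, with an expected range of 20000 nM to 100000 nM.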

Compound 4, half-maximal cytotoxic concentration in the CHO assay: 1700 nM
Estimate against measurement, compound 4: 26-fold (1.42 log units) above, and the stated range ends above it.
By their numbers in the CHO assay, from the lowest: compound 4; then compound 1; then compound 2; then compound 3.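

In the CHO assay, going from 4-(tert-butyl)piperazin-1-yl to 4-(cyclopropylmethyl)piperazin-1-yl gives a 58-fold lower number from compound 3 to compound 4 (1.77 log units; beyond the scatter), so exchanging one all-carbon group for another of equal heavy-atom count on this amine nitrogen can shift the read-out strongly. Cyclopropylmethyl does not by itself secure a high number: with hydrogen in place of fluoro on an aromatic carbon, the data show a 24-fold lower number from compound 2 to compound 4 (1.38 log units; beyond the scatter), which leaves compound 4 lowest of the four. In a physicochemical assay for solubility, read by HPLC, using the shake flask method, in phosphate buffer, measured as kinetic solubility, with a stated time of 20 h, at pH 6.5 (on this read-out lower numbers stand for lower solubility and higher numbers for higher solubility), compound 3 gives 50000 nM and compound 4 gives 130000 nM. Solubility moves the opposite way across the exchange from compound 3 to compound 4: the measured solubility of compound 3, 50000 nM, and of compound 4, 130000 nM, a 2.6-fold higher number (0.41 log units; beyond the scatter)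

Open, on these data alone, is how the fluoro-bearing counterpart of compound 3 would read, and so whether the effects of the two places simply add. Also open, as far as these compounds go, is whether a methyl group or a hydroxyethyl chain on the same nitrogen would read nearer compound 3 or compound 4.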